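Anilide aryl variation on the shared core

The source may hold more compounds than are shown below. What is called first, only, known or untested is meant among the compounds shown, and "the series" means these compounds.

Compound 2 `CN(C)C(=O)c1cc2cnc(Nc3ccc(NC(=O)C4(C(=O)Nc5cccc(F)c5)CC4)cc3)nc2n1C1CCCC1` stands at the lower of the two numbers in hand: in a functional assay on T47D cells (Homo sapiens) for inhibition, read by CCK-8 assay, with a stated time of 72 h, tested at 1 uM (a higher number here means more inhibition of growth at the concentration tested, a lower number less inhibition of growth), compound 2 gives -3.2%, whereas compound 1 `CN(C)C(=O)c1cc2cnc(Nc3ccc(NC(=O)C4(C(=O)Nc5ccc(O)cc5)CC4)cc3)nc2n1C1CCCC1` gives 91.5%. Among the compounds with values here, the one measured step, a number 94.7 percentage points lower from compound 1 to compound 2 (beyond the scatter), shows that putting 3-fluorophenyl in place of 4-hydroxyphenyl on the amide-type nitrogen removed essentially all growth inhibition. Compound 3 `CN(C)C(=O)c1cc2cnc(Nc3ccc(NC(=O)C4(C(=O)Nc5ccc(C(F)(F)F)cc5)CC4)cc3)nc2n1C1CCCC1` carries the change (4-(trifluoromethyl)phenyl in place of 3-fluorophenyl on an amide-type nitrogen). Within the data shown here, no measured step covers a move from one fluorinated aryl group to another at this position; the only step available bears on the loss of the 4-hydroxyphenyl, which compound 3 also lacks. A small step is therefore expected, a number 8.2 percentage points higher from compound 2 to compound 3 (within the scatter), with no direction that can be called beyond the scatter. Compound 3 is estimated at 5% in this assay, within a range from -15% to 35%.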

Compound 3, percent growth inhibition at one concentration: 29.6%
Estimate against measurement, compound 3: 24.6 percentage points below; measured number inside the range.
By their numbers in this assay, from the lowest: compound 2; then compound 3; then compound 1.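

In this assay, the aryl group on this amide-type nitrogen still matters once the 4-hydroxyphenyl is gone: 4-(trifluoromethyl)phenyl in place of 3-fluorophenyl gives a number 32.8 percentage points higher from compound 2 to compound 3 (beyond the scatter), so these two fluorinated aryl groups are not interchangeable. Trifluoromethyl in place of hydroxy on the aromatic carbon gives a number 61.9 percentage points lower from compound 1 to compound 3 (beyond the scatter), which shows that a fluorinated aryl group here can retain part of the growth inhibition of compound 1 without matching it. Nothing at hand gives a reason for either step.

The step between compound 2 and compound 3 changes both the fluorinated substituent and where it sits, and 4-fluorophenyl would help to separate the two. From the compounds shown here alone, whether 4-methoxyphenyl or 4-aminophenyl comes close to compound 1 also remains open.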